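This account rests on a few compounds, and the source may have more. Where it says the series, first, only, none or still open, it means among the compounds named here.

Working notes on the series. In an ADME assay on HepG2 cells (Homo sapiens) for cytotoxicity, with a stated time of 72 h (on this read-out higher numbers stand for an effect only at larger amounts of compound and lower numbers for an effect already at smaller amounts), compound 1 (`Cc1cc(NC(=O)Nc2ccccc2OC(F)(F)F)c2ccccc2n1`) gives > 25000 nM, which is a limit of the assay and not a number. Compound 3 (`Cc1cc(NC(=O)Nc2ccc(N(C)C)cc2)c2ccccc2n1`) gives > 25000 nM, which is also a limit. Going by the values given here, compound 2 (`Cc1cc(NC(=O)Nc2ccc(F)c(F)c2)c2ccccc2n1`), the one compound with a number, gives 21000 nM. Compound 1 stands at the limit of > 25000 nM in this assay, at which 2 of the 3 values shown sit.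

Compound 4 (`CSc1ccccc1NC(=O)Nc1cc(C)nc2ccccc12`) carries methylsulfanyl in place of trifluoromethoxy on an aromatic carbon, ortho to a large group: methylsulfanyl in place of trifluoromethoxy on an aromatic carbon. Among the compounds with values here, no measured pair in the set differs in one place, so the data give no direct size for this change. No step beyond the scatter is expected in this assay, and no direction is favoured. Within the data shown here, this expectation rests on compound 2, which at 21000 nM shows that no compound with a number acts at small amounts. The expected change is an at least 1.0-fold lower number from compound 1 to compound 4 (0.01 log units; that floor lies within the scatter). A further reading at the limit would not be surprising. For compound 4 the estimated value is 24000 nM, with an expected range of 11000 nM to 50000 nM.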

Compound 4, half-maximal effective concentration: > 25000 nM
Compound 4: only a limit was reported; the forecaster's own chance of this, stated with the estimate: 60%; middle value at least 1.0-fold (0.01 log units) from the limit.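

In this assay no step can be read between compound 1 and compound 4, because both results are limits of the assay and not numbers: the limit of > 25000 nM in this assay, at which 3 of the 4 values shown sit.

The compounds shown leave open whether methylsulfanyl in place of trifluoromethoxy changes the read-out at all, and in which direction.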